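A few compounds are considered here, and "the series" means these few. Any claim that something is new, unique, unknown or untested is made for them only; others in the source may bear on it.

In a functional assay on HL-60 cells (Homo sapiens) for antiproliferative activity, read by XTT assay, with a stated time of 72 h (a lower number here means a stronger inhibitor, a higher number a weaker inhibitor), compound 3 `CNc1ncnc2c1c(-c1cccs1)cn2[C@@H]1O[C@H](CO)[C@@H](O)[C@H]1O` gives > 20000 nM as its reading, and that is a limit, not a number. Compound 2 `CNc1ncnc2c1c(-c1ccoc1)cn2[C@@H]1O[C@H](CO)[C@@H](O)[C@H]1O` gives > 15000 nM as its reading, also a limit. Compound 1 `COc1ncnc2c1c(-c1ccccc1)cn2[C@@H]1O[C@H](CO)[C@@H](O)[C@H]1O` gives > 20000 nM as its reading, again a limit. The three readings thus sit at the limit of > 15000 nM in this assay, at which 1 of the 3 values shown sits, and at the limit of > 20000 nM in this assay, at which 2 of the 3 values shown sit, and none of them is a number.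

Compound 4 `CNc1ncnc2c1c(-c1ccccc1)cn2[C@@H]1O[C@H](CO)[C@@H](O)[C@H]1O` arises from compound 3 through one change phenyl in place of thiophen-2-yl on an aromatic carbon with phenyl in place of thiophen-2-yl on an aromatic carbon. For the measured compounds named here, the only measured step is a step that the two limits leave unreadable from compound 2 to compound 3 and it offers no size to carry over. Compound 1 carries phenyl too, though it differs from compound 4 elsewhere on the shared core, and it gave no number either.

The expected step is a step that the limit leaves unreadable from compound 3 to compound 4 with no change beyond the scatter and no direction foreseen in this assay for this swap. For compound 4 the estimate is 25000 nM with an expected range from 8000 nM to 60000 nM and another limit is the likeliest report.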

Compound 4, half-maximal inhibitory concentration: > 20000 nM
Compound 4: a limit, no number; the forecaster's own chance of this, stated with the estimate: 85%; the middle value does not contradict the limit.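

In this assay compound 4 gives > 20000 nM, a limit and not a number. The steps to compound 4 from compound 1, compound 2 and compound 3 cannot be read, as each pair has only limits. The compounds shown leave open whether any of these changes alters activity, and by how much.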